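Methoxy added to the lower of two measured compounds

The source may report more compounds than this note shows. Statements on the series, on what has been measured and on what is new or still open speak of the compounds shown alone.

For the measured compounds named here, in a functional assay on SN12C cells (Homo sapiens) for inhibition, read by sulforhodamine B assay, with a stated time of 48 h, tested at 10 uM (on this read-out higher numbers stand for more inhibition of growth at the one concentration tested and lower numbers for less inhibition of growth), compound 2 (`Clc1ccc(-c2cn3nc(-c4ccccc4)nc3s2)cc1`) gives 22% as the lower of the two numbers so far. Compound 1 (`COc1ccc(-c2nc3sc(-c4ccccc4)cn3n2)cc1`) gives 37% in this assay and lies above compound 2 beyond the scatter. Compound 3 (`COc1ccc(-c2nc3sc(-c4ccc(Cl)cc4)cn3n2)cc1`) comes from compound 2 by methoxy in place of hydrogen on an aromatic carbon with methoxy in place of hydrogen on an aromatic carbon. Compound 1 at 37% also carries methoxy, but it differs from compound 2 in more than one place, so this is weak support. An upward change of a number 11 percentage points higher from compound 2 to compound 3 (beyond the scatter) is expected in this assay with wide uncertainty. Compound 3 is estimated at 33% with an expected range from 16% to 52% in this read-out.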

Compound 3, percent growth inhibition at one concentration: 94.7%
Estimate against measurement, compound 3: 61.7 percentage points below; the measured number lies above the stated range.
By their numbers in this assay, from the lowest: compound 2; then compound 1; then compound 3.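

With chloro held in place, methoxy in place of hydrogen on an aromatic carbon, para to a large group, gives a number 72.7 percentage points higher from compound 2 to compound 3 (beyond the scatter) in this assay. With methoxy held in place, chloro in place of hydrogen on an aromatic carbon gives a number 57.7 percentage points higher from compound 1 to compound 3 (beyond the scatter). Each group therefore counts heavily when the other is present, which compound 1 and compound 2 could not show on their own, and nothing available explains these steps.

From the compounds shown here alone, it remains open whether methoxy gives a similar step without chloro. Also open, going by these compounds, is whether an amine or a longer alkoxy chain at the methoxy place would keep the number of compound 3.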